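This account rests on a few compounds, and the source may have more. Where it says the series, first, only, none or still open, it means among the compounds named here.

Measured in an ADME assay on microsomes (Rattus norvegicus) for metabolic stability; on this read-out lower numbers stand for a shorter-lived compound and higher numbers for a longer-lived compound:

Compound 1 `Cc1ccc(C2CC=NN2C(=O)C(C)(C)C)cc1`: 0.0383 h
Compound 2 `O=C(c1ccccc1)N1CCC(C(=O)N2N=CCC2c2ccccc2)CC1`: 0.0833 h
Compound 3 `CC(C)(C)C(=O)N1CCSC1c1ccccc1`: 0.0533 h

Compound 2, at 0.0833 h, has the highest number of the three when set against compound 1, and that gap lies beyond the usual scatter of repeated measurements. Its gap to compound 3 lies within that scatter, so those two cannot be told apart in this assay.

The next compound to be tested is compound 4 `O=C(C1CCN(C(=O)C(F)(F)F)CC1)N1N=CCC1c1ccccc1`. It differs from compound 2 in one place: trifluoromethyl in place of phenyl on a carbonyl carbon. Put simply, trifluoromethyl takes the place of phenyl on a carbonyl carbon, which turns a benzoyl into a (trifluoromethyl)carbonyl.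

Within the data shown here, no pair of measured compounds shows this exchange, or any other single change, so the data offer no direct guide to its size or direction. Among the measured compounds shown here, the only guide is the narrow band of values, which runs from compound 1 at 0.0383 h to compound 2 at 0.0833 h. A result near compound 2 therefore seems the most reasonable expectation. The expected change, a 1.1-fold higher number from compound 2 to compound 4 (0.03 log units; within the scatter), is no larger than the scatter. For compound 4 the estimated half-life is 0.09 h, with an expected range from 0.045 h to 0.18 h.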

Compound 4, half-life: 0.483 h
Beside the measured number, compound 4's estimate is 5.4-fold (0.73 log units) below it; measured number outside the range, above it.
By their numbers in this assay, from the lowest: compounds 1, 3 and 2 (each within the scatter of the next, the first and the last beyond it); then compound 4.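

Swapping phenyl for trifluoromethyl on this carbonyl carbon gives a 5.8-fold higher number from compound 2 to compound 4 (0.76 log units; beyond the scatter) in this assay, a first direct reading of how far a single change can move the half-life in this set. It shows that the group on this carbonyl carbon, whose other neighbour is an amide-type nitrogen in a ring, is not a silent spot. The shift in the number on going from benzoyl to (trifluoromethyl)carbonyl lies beyond the usual scatter of repeated measurements. Nothing available here accounts for why the half-life rises with this exchange.

From the compounds shown here alone, this is one pair, so it remains open whether the rise comes from the trifluoromethyl itself or simply from the departure of the phenyl ring, and a cyclopropyl or an ethyl on the same carbonyl carbon would help to separate those two readings. Going by these compounds, it also remains open whether the same exchange would give a step of similar size on another core, or whether it holds only for the core shared by compound 2 and compound 4.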